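The source may hold more compounds than are shown below. What is called first, only, known or untested is meant among the compounds shown, and "the series" means these compounds.

Of the compounds shown here, two sharing one core have been measured in an assay on HEK293 cells for inhibition of Steryl-sulfatase (Homo sapiens), tested at 0.1 uM; a higher number here means a stronger effect of the compound at the concentration tested, a lower number a weaker effect. Compound 1 `CN(C)CCN(CCN(C)C)c1ccc(C(=O)N2CCc3ccc(OS(N)(=O)=O)cc3C2)cc1` gives 3.8% in this assay, and compound 2 `CCN(Cc1ccccc1)Cc1ccc(CN2CCc3ccc(OS(N)(=O)=O)cc3C2)cc1` gives 1%. Compound 1 holds the higher of these two numbers, but its gap to compound 2 lies within the scatter, so the two readings are not distinguishable; both show little inhibition at the concentration tested.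

Compound 3 `CCN(Cc1ccncc1)c1ccc(C(=O)N2CCc3ccc(OS(N)(=O)=O)cc3C2)cc1` has not yet been measured. It differs from compound 1 in one place: ethyl((pyridin-4-yl)methyl)amino in place of bis(2-(dimethylamino)ethyl)amino on an aromatic carbon. Within the data shown here, no two measured compounds differ in a single place, so there is no measured step of this kind to lean on. Because compound 1 gives 3.8% and compound 2 gives 1%, both near the bottom of the scale, no step beyond the scatter is expected in this assay. The expected step is a number 0.8 percentage points lower from compound 1 to compound 3 (within the scatter), essentially none. Compound 3 is therefore estimated at 3%, with a range from 0% to 12%.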

Compound 3, a percentage reported as inhibition, at one concentration (the size of the read-out at that concentration, not a potency): 47%
Estimate against measurement, compound 3: 44 percentage points below; the measured number lies above the stated range.
By their numbers in this assay, from the lowest: compounds 2 and 1 (each within the scatter of the next); then compound 3.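

In this assay, the aromatic carbon para to a large group proves sensitive to what it carries: ethyl((pyridin-4-yl)methyl)amino in place of bis(2-(dimethylamino)ethyl)amino gives a number 43.2 percentage points higher from compound 1 to compound 3 (beyond the scatter). Compounds 1 and 2 gave no hint of this, as both read low and could not be told apart. The entering group brings a six-membered aromatic ring with 1 hetero atom where the leaving group has no ring, but nothing measured here explains why the change has this effect.

Several features change together in this swap, so it remains open which part of the entering group carries the step. A (pyridin-3-yl)methyl group in place of the (pyridin-4-yl)methyl, or a methyl in place of the ethyl, would test the ring nitrogen and the small chain separately.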